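This account rests on a few compounds, and the source may have more. Where it says the series, first, only, none or still open, it means among the compounds named here.

Compound 1 `Nc1ccc(-c2nc3ccccc3s2)cc1I` and compound 2 `Nc1ccc(-c2nc3ccccc3s2)cc1Cl` share a core and differ only in carrying iodo or chloro. In a functional assay on MCF7 cells (Homo sapiens) for cytotoxicity (on this read-out lower numbers stand for stronger inhibition and higher numbers for weaker inhibition), compound 1 gives < 1 nM, which is a limit of the assay and not a number. Compound 2 gives < 1 nM, which is also a limit. Between them lies a step that the two limits leave unreadable from compound 1 to compound 2, so this swap offers no size to carry over.

Going by the values given here, compound 3 `CC(=O)ON(C(C)=O)c1ccc(-c2nc3ccccc3s2)cc1C` gives 55 nM, the only true number among the three. Compound 4 `Cc1cc(-c2nc3ccccc3s2)ccc1N` has not yet been measured. It keeps the methyl group of compound 3 but has amino in place of acetoxy(acetyl)amino on an aromatic carbon.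

Among the compounds with values here, no measured step shows this exact change, so the best guide is the limit of < 1 nM in this assay, at which 2 of the 3 values shown sit. That limit is held by compound 1 and compound 2, which carry the same amino group as compound 4, with iodo or chloro in place of its methyl. On that basis, a large move toward stronger inhibition is expected, possibly reaching the limit itself. The estimated change is a 69-fold lower number from compound 3 to compound 4 (1.84 log units; beyond the scatter). For compound 4 the expected value is 0.8 nM, with an estimated range of 0.1 nM to 8 nM.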

Compound 4, half-maximal inhibitory concentration: < 1 nM
Compound 4: a limit, no number (the forecaster's own chance of this, stated with the estimate: 60%); the middle value does not contradict the limit.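

With the methyl group held in place, putting amino in place of acetoxy(acetyl)amino on this aromatic carbon, ortho to a methyl group, gives in this assay an at least 55-fold lower number from compound 3 to compound 4 (1.74 log units; beyond the scatter). This is the first comparison shown that isolates this change, and its size is only a minimum, as the result for compound 4 is a limit of the assay and not a number. Compound 4 also joins compound 1 and compound 2, so all three compounds shown with the amino group sit at that limit, while compound 3, the one compound shown without it, gives a true number.

As far as these compounds go, the steps among compound 1, compound 2 and compound 4 cannot be read, so methyl, chloro and iodo cannot be ordered at this position, and the assay offers no room to separate them: the limit of < 1 nM in this assay, at which 3 of the 4 values shown sit. Also open is which part of acetoxy(acetyl)amino goes with the weaker number, which a simple acetamido or hydroxyamino group at this carbon could help to show, and whether a methoxy group in place of the methyl would keep the amino compounds at the limit.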